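The compounds below may be only part of what the source reports. "The series", "measured", "known", "first", "only" and "open" are said of these compounds alone.

In a functional assay for inhibition, with Homo sapiens as the target (a higher number here means a weaker inhibitor, a lower number a stronger inhibitor), compound 3 `Sc1nncc2cncn12` gives > 48000 nM, which is a limit of the assay rather than a number. Compound 1 `CNc1nncc2cncn12` gives > 48000 nM in this assay, again only a limit. Going by the values given here, compound 2 `CC(C)CCSc1nncc2cncn12` is the one member of the set with a measured number, 9000 nM in this assay. Compound 3 therefore stands at the weak end of what is shown, together with compound 1 at the limit of > 48000 nM in this assay, at which 2 of the 3 values shown sit.

Compound 4 `CCCc1ncn2c(S)nncc12` differs from compound 3 by propyl in place of hydrogen on an aromatic carbon. Two measured steps lead into compound 3. The step that the two limits leave unreadable from compound 1 to compound 3 is unreadable, both ends being limits. The step of an at least 5.3-fold higher number from compound 2 to compound 3 (0.72 log units; beyond the scatter) shows that removing a chain of carbons from compound 2 pushed the number out to the limit; that chain sat on the sulfur, not on the ring carbon where the propyl of compound 4 enters, so it bears only loosely on the present change. A step of about an at least 1.6-fold lower number from compound 3 to compound 4 (0.20 log units; that floor lies within the scatter) in this assay is therefore expected, toward a lower number but quite possibly still at a limit. Compound 4 is estimated at 30000 nM in this assay, within 8000 nM to 100000 nM.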

Compound 4, half-maximal inhibitory concentration: > 48000 nM
Compound 4 gave a limit, no number (the forecaster's own chance of this, stated with the estimate: 60%); at least 1.6-fold (0.20 log units) between middle value and limit.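

In this assay compound 3 and compound 4 both give only a limit, so no step can be read between them. The compounds shown leave open whether propyl in place of hydrogen on that aromatic carbon moves the number in either direction.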